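The compounds below may be only part of what the source reports. "The series", "measured", "known", "first", "only" and "open" are said of these compounds alone.

Measured so far (a functional assay on HCT-116 cells (Homo sapiens) for inhibition, read by MTT assay, with a stated time of 72 h; on this read-out lower numbers stand for stronger inhibition and higher numbers for weaker inhibition):
- compound 1 (`Nc1ncnc2c1c(-c1cnc3[nH]ccc3c1)nn2CCCCC(=O)NO`) gives > 150000 nM (a limit)
- compound 2 (`Nc1ncnc2c1c(-c1cnc3[nH]ccc3c1)nn2CCCCCCCCCC(=O)NO`) gives 18700 nM
- compound 3 (`Nc1ncnc2c1c(-c1cnc3[nH]ccc3c1)nn2CCC(=O)NO`) gives > 150000 nM (a limit)

Compound 3 stands at the limit of > 150000 nM in this assay, at which 2 of the 3 values shown sit (a limit, not a number). Compound 4 (`Nc1ncnc2c1c(-c1cnc3[nH]ccc3c1)nn2CCCC(=O)NO`) differs from compound 3 by (hydroxycarbamoyl)methyl in place of hydroxycarbamoyl on a saturated chain carbon, two bonds along the chain from an aromatic nitrogen (in words, 2-(hydroxycarbamoyl)ethyl to 3-(hydroxycarbamoyl)propyl). Its chain is longer than that of compound 3 and shorter than that of compound 1. The limits leave one bearing step without size (a step that the two limits leave unreadable from compound 1 to compound 3). Going by the values given here, the only readable step (an at least 8.0-fold lower number from compound 1 to compound 2 (0.90 log units; beyond the scatter)) goes to a much longer chain. No step beyond the scatter is therefore expected in this assay, and a further limit is likely. The expected step is a number no higher from compound 3 to compound 4 (the limit leaves the size open) (an estimate). Compound 4 is estimated at 150000 nM (expected range 80000 nM to 300000 nM).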

Compound 4, half-maximal inhibitory concentration: > 150000 nM
Compound 4: only a limit was reported; the forecaster's own chance of this, stated with the estimate: 85%; the middle value lies on the limit itself.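

In this assay compound 4 also returns only a limit, > 150000 nM, so the 3-(hydroxycarbamoyl)propyl chain adds no measurable number to the short-chain end of the series: the limit of > 150000 nM in this assay, at which 3 of the 4 values shown sit. The steps among compound 1, compound 3 and compound 4 cannot be read. Going by these compounds alone, the one readable new step, an at least 8.0-fold higher number from compound 2 to compound 4 (0.90 log units; beyond the scatter), leaves compound 2 as the only compound with a measured number.

Open, as far as these compounds go, is where, at chain lengths between those of compound 1 and compound 2, a measured number first appears. Also open, from the compounds shown here alone, is what a longer chain, or a carboxylic acid in place of hydroxycarbamoyl, would give.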